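The source may hold more compounds than are shown below. What is called first, only, known or untested is meant among the compounds shown, and "the series" means these compounds.

Measured compounds in a functional assay on CCRF-CEM cells (Homo sapiens) for cytotoxicity, read by cell counting, with a stated time of 3 days; on this read-out lower numbers stand for stronger inhibition and higher numbers for weaker inhibition: compound 1 `CC(C)(C)c1ccc(CN2C(=O)S/C(=C\c3cccc(N)c3)C2=O)cc1` gives 165000 nM; compound 2 `C=C(Br)C(=O)Nc1cccc(/C=C2\SC(=O)N(Cc3cccc(F)c3)C2=O)c1` gives 690 nM; compound 3 `C=C(Br)C(=O)Nc1cccc(/C=C2\SC(=O)N(Cc3ccc(C(C)(C)C)cc3)C2=O)c1` gives 3000 nM.

Compound 3 holds the second highest number of the three in this assay, a 4.3-fold higher number from compound 2 to compound 3 (0.64 log units; beyond the scatter) separating it from compound 2 and a 55-fold lower number from compound 1 to compound 3 (1.74 log units; beyond the scatter) from compound 1. Compound 4 `C=C(Br)C(=O)Nc1cccc(/C=C2\SC(=O)N(Cc3ccccc3)C2=O)c1` differs from compound 3 only in hydrogen in place of tert-butyl on an aromatic carbon. The step of a 4.3-fold higher number from compound 2 to compound 3 (0.64 log units; beyond the scatter) bears directly on this, as it also alters the group on the ring bound to the saturated chain carbon; the step from compound 1 to compound 3 concerns a different site. A modest lowering of the number is therefore expected for compound 4, with a 2.5-fold lower number from compound 3 to compound 4 (0.40 log units; beyond the scatter) in this assay. The estimate for compound 4 is 1200 nM, ranging from 400 nM to 4000 nM.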

Compound 4, half-maximal inhibitory concentration: 510 nM
Beside the measured number, compound 4's estimate is 2.4-fold (0.37 log units) above it; the range from low to high includes it.
By their numbers in this assay, from the lowest: compounds 4 and 2 (each within the scatter of the next); then compound 3; then compound 1.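

In this assay, hydrogen in place of tert-butyl gives a 5.9-fold lower number from compound 3 to compound 4 (0.77 log units; beyond the scatter) and so isolates the tert-butyl as the change that raises the number within this series. Hydrogen in place of fluoro gives a 1.4-fold lower number from compound 2 to compound 4 (0.13 log units; within the scatter) and lies within the scatter, so the phenyl and 3-fluorophenyl groups cannot be told apart here. Nothing measured here explains the effect of the tert-butyl. The compounds shown leave open how a methyl, methoxy, amine or carboxylic acid on this aromatic carbon would compare. They also leave open whether a group of intermediate size, such as isopropyl, would already raise the number.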